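Replacing chloro with fluoro on compound 3

The source may hold more compounds than are shown below. What is called first, only, known or untested is meant among the compounds shown, and "the series" means these compounds.

In a functional assay on PC-3 cells (Homo sapiens) for cytotoxicity, read by MTT assay (on this read-out higher numbers stand for weaker inhibition and lower numbers for stronger inhibition), compound 3 (`COc1ccc2cc([C@H](C)c3nnc(SCc4ccc(F)cc4)n3-c3ccc(Cl)cc3)ccc2c1`) gives 10800 nM as the lowest number shown. Compound 2 (`COc1ccc2cc([C@H](C)c3nnc(SCc4ccc(C)cc4)n3-c3ccc(F)cc3)ccc2c1`) reads 229000 nM and stands higher. Compound 1 (`COc1ccc2cc([C@H](C)c3nnc(SCc4ccc(Cl)cc4)n3-c3ccc(F)cc3)ccc2c1`) gives <= 400000 nM as a limit of the assay and not a number. Going by the values given here, the only measured step is a step that the limit leaves unreadable from compound 1 to compound 2 and it offers no size to carry over. Compound 4 (`COc1ccc2cc([C@H](C)c3nnc(SCc4ccc(F)cc4)n3-c3ccc(F)cc3)ccc2c1`) arises from compound 3 through fluoro in place of chloro on an aromatic carbon as fluoro in place of chloro on an aromatic carbon. Compound 2 already carries that 4-fluorophenyl and reads 229000 nM although it also differs elsewhere. The expected change is a 5.6-fold higher number from compound 3 to compound 4 (0.74 log units; beyond the scatter) towards a higher number. For compound 4 the expected value is 60000 nM with a range of 12000 nM to 250000 nM as estimated.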

Compound 4, half-maximal inhibitory concentration: <= 400000 nM
Compound 4 ended at the assay's limit (the forecaster's own chance of this, stated with the estimate: 15%); the middle value lies beyond the limit too.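

Going by these compounds alone, no step to compound 4 from compound 1, compound 2 or compound 3 can be read, because compound 4 gives a limit and not a number: the limit of <= 400000 nM in this assay, at which 2 of the 4 values shown sit. Left open is how large the change from 4-chlorophenyl to 4-fluorophenyl is between compound 3 and compound 4.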